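The source may report more compounds than this note shows. Statements on the series, on what has been measured and on what is new or still open speak of the compounds shown alone.

Working notes on the series. The reference point is compound 1 `Cc1nc(C2CC2)cc2nn(-c3ccccc3)cc12`, carrying a cyclopropyl group and a methyl group on the shared core. In a functional assay on MCF7 cells (Homo sapiens) for inhibition, read by fluorescence, with a stated time of 72 h (on this read-out higher numbers stand for weaker inhibition of growth and lower numbers for stronger inhibition of growth), compound 1 gives 63500 nM. Compound 2 `CCCCc1cc2nn(-c3ccccc3)cc2c(C(C)C)n1` gives 33300 nM in this assay; the two numbers sit within the usual scatter of each other, so no order between compound 1 and compound 2 can be read from them. Compound 3 `Cn1cc2cnc(-c3ccccc3)cc2n1` gives > 100000 nM in this assay, which is a limit of the assay and not a number; this is the limit of > 100000 nM in this assay, at which 1 of the 3 values shown sits. Compound 1 thus holds the higher of the two real numbers, with one further value being a limit.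

The step under consideration leads to compound 4 `CCCCCc1cc2nn(-c3ccccc3)cc2c(C)n1`, not yet measured. The change is pentyl in place of cyclopropyl on an aromatic carbon, in words pentyl in place of cyclopropyl on an aromatic carbon. Going by the values given here, no measured pair in this set differs in one place, so the size of the step rests on expectation alone. Compound 2 carries a butyl chain and its value of 33300 nM lies within scatter of compound 1, which gives no sign that a straight chain moves the number far. The step of a 1.4-fold lower number from compound 1 to compound 4 (0.15 log units; within the scatter) is therefore expected to fall within or near the scatter, with no clear direction. The estimate for compound 4 is 45000 nM, with a range from 15000 nM to 130000 nM.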

Compound 4, concentration for 50% growth inhibition: 17000 nM
Estimate against measurement, compound 4: 2.6-fold (0.42 log units) above, and the stated range covers the measured number.
By their numbers in this assay, from the lowest: compounds 4, 2 and 1 (each within the scatter of the next, the first and the last beyond it). At a limit, above all of these: compound 3.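

In this assay, going by these compounds alone, the exchange of cyclopropyl for pentyl gives a 3.7-fold lower number from compound 1 to compound 4 (0.57 log units; beyond the scatter), and this is the only step in the set that changes a single place. It shows that the aromatic carbon next to the ring nitrogen is not indifferent to the group it carries: a chain with no ring, set there on the otherwise unchanged shared core, gives a modest but readable drop in the number, and compound 4 stands at 17000 nM. Nothing measured in this set bears on what lies behind this step.

The compounds shown leave open whether the length of the chain or the loss of the three-membered ring drives the step, and compound 2 differs from compound 1 in more than one place, so it cannot settle the question. Also open, as far as these compounds go, is how this position would answer to a shorter propyl chain, a longer heptyl chain, or a pentyl chain ending in an amine or a carboxylic acid.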